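This account rests on a few compounds, and the source may have more. Where it says the series, first, only, none or still open, it means among the compounds named here.

Measured compounds:
- compound 1, `CCN(c1ccc(C#N)c(Cl)c1)c1cc(-c2ccncc2)ccc1C`: 3580 nM
- compound 2, `N#Cc1ccc(N2CCc3cc(-c4cccnc4)ccc32)cc1C(F)(F)F`: "not determined" (no result reported)

In a functional assay on PC-3 cells (Homo sapiens) for antiproliferative activity, read by CCK-8 assay, with a stated time of 6 days (a higher number here means a weaker inhibitor, a lower number a stronger inhibitor), compound 1 gives 3580 nM. For the measured compounds named here, this is the only number available; compound 2 carries no numerical result in this assay, so compound 1 stands alone and cannot be ranked against anything.

Compound 3, `CCN(c1ccc(C#N)c(Cl)c1)c1cc(-n2cccn2)ccc1C`, is to be measured next. It differs from compound 1 in one place: 1H-pyrazol-1-yl in place of pyridin-4-yl on an aromatic carbon. The change sits on an aromatic carbon of a six-membered aromatic ring of carbon only, meta to a large group and para to a methyl group. Going by the values given here, no pair of measured compounds shows what this kind of change does in this assay, so the size of the step is not known from the data.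

The expectation for the step is a small shift toward a weaker inhibitor, of a size that may not exceed the scatter, so that a 1.4-fold higher number from compound 1 to compound 3 (0.15 log units; within the scatter) is what is estimated. Compound 3 is expected to give about 5000 nM in this assay, within a range of 1500 nM to 15000 nM.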

Compound 3, half-maximal inhibitory concentration: 15700 nM
Compound 3: the middle estimate sits 3.1-fold (0.50 log units) below what was measured, outside the stated range (above it).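

For the compounds shown here, at the aromatic carbon para to the methyl group, the exchange of pyridin-4-yl for 1H-pyrazol-1-yl is not silent: in this assay it gives a 4.4-fold higher number from compound 1 to compound 3 (0.64 log units; beyond the scatter), the first step that can be read at all. The position therefore responds to which aromatic ring it carries, and of the two rings tested on this core, pyridin-4-yl goes with the stronger inhibitor. The change alters ring size and the number of hetero atoms together, and nothing available bears on the reason for the step.

From the compounds shown here alone, with one pair, it remains open whether ring size or the number and placement of the ring nitrogens governs the shift, and a pyridin-3-yl or pyridin-2-yl group on the core of compound 1 would help separate these. Also open, going by these compounds, is how far the position tolerates anything other than an aromatic ring, such as a morpholine, an aminomethyl group or a carboxylic acid.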